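The compounds below may be only part of what the source reports. "The series", "measured", "known", "first", "only" and "open" are said of these compounds alone.

The three measured compounds share a scaffold bearing a triazole that carries an aryl group, and they were tested in a functional assay on SMMC-7721 cells (Homo sapiens) for cytotoxicity, read by MTT assay, with a stated time of 4 days; a higher number here means a weaker inhibitor, a lower number a stronger inhibitor. Compound 1 `C=C1C(=O)[C@]23C[C@@]1(O)CC[C@H]2c1ccc(OS(=O)(=O)c2ccc(C)cc2)c(C)c1[C@@H]3Cn1cc(-c2ccccn2)nn1`, whose core carries a ketone and a tosylate, gives 2830 nM in this assay. Compound 2 `C=C1C[C@]23C[C@@]1(O)CC[C@@H]2c1cccc(C)c1[C@@H]3Cn1cc(-c2ccc(OC)cc2)nn1` carries a methoxyphenyl on the triazole, and in this assay compound 2 reaches only the limit > 20000 nM, which is a boundary of the assay and not a number. Compound 3 `C=C1C[C@]23C[C@@]1(O)CC[C@@H]2c1cccc(C)c1[C@@H]3Cn1cc(-c2ccccc2)nn1` carries a plain phenyl on the triazole, and in this assay compound 3 likewise sits at the limit > 20000 nM, again a boundary rather than a number. The step that the two limits leave unreadable from compound 2 to compound 3 therefore cannot be read in size, since (the limit of > 20000 nM in this assay, at which 2 of the 3 values shown sit). Compound 4 `C=C1C[C@]23C[C@@]1(O)CC[C@@H]2c1cccc(C)c1[C@@H]3Cn1cc(-c2ccc(C)cc2)nn1` differs from compound 3 by methyl in place of hydrogen on an aromatic carbon. Among the measured compounds shown here, no measured step speaks to such a change, and the only comparison that exists, between compound 2 and compound 3, is unreadable. Compound 4 is therefore expected to remain at or near the limit, with an estimated step that the limit leaves unreadable from compound 3 to compound 4. The value for compound 4 is estimated at 25000 nM, within 8000 nM to 60000 nM.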

Compound 4, half-maximal inhibitory concentration: > 20000 nM
Compound 4: only a limit was reported (the forecaster's own chance of this, stated with the estimate: 75%); the middle value lies beyond the limit too.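

Compound 4 sits at a limit of the assay, as do compound 2 and compound 3, so no step among these three compounds can be read in size: the limit of > 20000 nM in this assay, at which 3 of the 4 values shown sit. The compounds shown leave open whether changing the group on the triazole's phenyl ring alters the result in this assay at all.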